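The source may hold more compounds than are shown below. What is called first, only, known or untested is meant among the compounds shown, and "the series" means these compounds.

Compound 2 `CCNS(=O)(=O)c1ccc(S(=O)(=O)N2CCC[C@@H](C(=O)N3CCN(c4nc(C(C)C)no4)CC3)C2)cc1` gives the highest of the two numbers seen in a functional assay on BXPC-3 cells (Homo sapiens) for inhibition, read by MTT assay, with a stated time of 7 days (on this read-out higher numbers stand for weaker inhibition and lower numbers for stronger inhibition), at 6900 nM. Going by the values given here, its nearest neighbour is compound 1 `CC(C)c1noc(N2CCN(C(=O)[C@@H]3CCCN(S(=O)(=O)c4ccc(S(=O)(=O)NC(C)(C)C)cc4)C3)CC2)n1`, which in this assay gives 2600 nM; the change a 2.7-fold higher number from compound 1 to compound 2 (0.42 log units; beyond the scatter) is the only measured step. Compound 3 `CCC(CC)S(=O)(=O)c1ccc(S(=O)(=O)N2CCC[C@@H](C(=O)N3CCN(c4nc(C(C)C)no4)CC3)C2)cc1` has not been measured; it carries pentan-3-yl in place of ethylamino on a sulfonyl sulfur. From the compounds shown here alone, because the step of a 2.7-fold higher number from compound 1 to compound 2 (0.42 log units; beyond the scatter) shows a larger alkyl group paired with the lower number, a modest return toward lower numbers is expected, though the loss of the hydrogen-bond donor is untested, so compound 3 is estimated at 3500 nM, within 1200 nM to 10000 nM, meaning a 2.0-fold lower number from compound 2 to compound 3 (0.29 log units; within the scatter).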

Compound 3, half-maximal inhibitory concentration: 120 nM
Compound 3: middle estimate off by 29-fold (1.46 log units), on the high side; the whole stated range lies above it.
By their numbers in this assay, from the lowest: compound 3; then compound 1; then compound 2.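

In this assay the group on this sulfonyl sulfur moves the number much further than the alkyl change on the sulfonamide nitrogen did: pentan-3-yl gives a 58-fold lower number from compound 2 to compound 3 (1.76 log units; beyond the scatter) and also a 22-fold lower number from compound 1 to compound 3 (1.34 log units; beyond the scatter) as it replaces each amino group. Each step removes the amino nitrogen and changes the alkyl group together, so these compounds cannot separate the two. No evidence here accounts for the size of these steps. The compounds shown leave open whether ethyl joined directly to the sulfur would keep the low number. From the compounds shown here alone, whether cyclopentyl or a longer chain would do so also remains open.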